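One Added Methyl on the Isopropoxy Chain

A few compounds are considered here, and "the series" means these few. Any claim that something is new, unique, unknown or untested is made for them only; others in the source may bear on it.

In a functional assay on LNCaP cells (Homo sapiens) for antiproliferative activity, read by WST assay, with a stated time of 3 days (on this read-out higher numbers stand for weaker inhibition and lower numbers for stronger inhibition), compound 3 (`COc1cc(-c2oc3ccccc3c(=O)c2OC(C)C)cc(OC)c1OC`) gives 8800 nM. Its pentyl relative, compound 1 (`CCCCCOc1c(-c2cc(OC)c(OC)c(OC)c2)oc2ccccc2c1=O`), gives 15400 nM, and its hexyl relative, compound 2 (`CCCCCCOc1c(-c2cc(OC)c(OC)c(OC)c2)oc2ccccc2c1=O`), gives 19600 nM. Compound 3 therefore stands apart only from the hexyl member of the set: a 1.8-fold lower number from compound 1 to compound 3 (0.24 log units; within the scatter), whereas a 2.2-fold lower number from compound 2 to compound 3 (0.35 log units; beyond the scatter).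

Compound 4 (`CCC(C)Oc1c(-c2cc(OC)c(OC)c(OC)c2)oc2ccccc2c1=O`), not yet measured, carries sec-butoxy in place of isopropoxy on the same core, the change being (methyl in place of hydrogen on a saturated chain carbon, two bonds along the chain from an oxygen on an aromatic ring).

Among the compounds with values here, the closest precedent is the same kind of addition farther out on the chain, five bonds along from the oxygen, where compound 1 and compound 2 show a 1.3-fold higher number from compound 1 to compound 2 (0.10 log units; within the scatter). The swaps of isopropyl for the longer chains are also small, and both point to a slightly higher number as the chain grows. A small rise, probably within the scatter, is therefore expected in this assay. The expected step is a 1.3-fold higher number from compound 3 to compound 4 (0.12 log units; within the scatter). For compound 4 the estimated value is 11500 nM, with an expected range from 6000 nM to 20000 nM.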

Compound 4, half-maximal inhibitory concentration: 9300 nM
For compound 4 the middle estimate is 1.2-fold (0.09 log units) above the measured one; measured number inside the range.
By their numbers in this assay, from the lowest: compounds 3, 4, 1 and 2 (each within the scatter of the next, the first and the last beyond it).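

Adding methyl at this place, two bonds along the chain from an oxygen on an aromatic ring, does not separate the two branched ethers in this assay: the result is a 1.1-fold higher number from compound 3 to compound 4 (0.02 log units; within the scatter). The sec-butoxy member also holds the same standing as the isopropoxy member against the straight chains: sec-butyl in place of hexyl gives a 2.1-fold lower number from compound 2 to compound 4 (0.32 log units; beyond the scatter), whereas sec-butyl in place of pentyl gives a 1.7-fold lower number from compound 1 to compound 4 (0.22 log units; within the scatter). Methyl addition thus reads alike close to the oxygen and five bonds along the chain: the same change on two cores in this assay, a 1.3-fold higher number (0.10 log units; within the scatter) from compound 1 to compound 2 and a 1.1-fold higher number (0.02 log units; within the scatter) from compound 3 to compound 4, 1.2-fold (0.08 log units) apart, within the scatter of two such steps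

The compounds shown cover only a few simple alkyl ethers on the shared core. From the compounds shown here alone, whether a tert-butyl group, a cyclopentyl ring or a chain ending in an amine on that oxygen would move the number beyond the scatter stays open.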